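The source may hold more compounds than are shown below. What is called first, only, known or untested is meant among the compounds shown, and "the series" means these compounds.

In a functional assay on HeLa cells (Homo sapiens) for antiproliferative activity, read by sulforhodamine B assay, with a stated time of 72 h (on this read-out lower numbers stand for stronger inhibition and higher numbers for weaker inhibition), compound 1 `COc1ccc(C)cc1NC(=S)N/N=C/c1ccc2ccccc2n1` gives only a limit of the assay, > 100000 nM. Compound 2 `S=C(N/N=C/c1ccc2ccccc2n1)Nc1ccc(Br)cc1` gives 56800 nM, and compound 3 `S=C(N/N=C/c1ccc2ccccc2n1)Nc1cccc(Cl)c1` gives 52500 nM. Compound 3 stands nearest to compound 2, and the step of a 1.1-fold lower number from compound 2 to compound 3 (0.03 log units; within the scatter) keeps the two within the scatter of each other. Compound 4 `Cc1ccccc1NC(=S)N/N=C/c1ccc2ccccc2n1` differs from compound 3 in one place: 2-methylphenyl in place of 3-chlorophenyl on an amide-type nitrogen. For the measured compounds named here, the only measured step, a 1.1-fold lower number from compound 2 to compound 3 (0.03 log units; within the scatter), likewise exchanges one substituted phenyl for another on the same amide-type nitrogen and stays within the scatter, so no step beyond the scatter is expected from this change either. Compound 4 is therefore estimated at 60000 nM, with a range from 25000 nM to 140000 nM. The expected step is a 1.1-fold higher number from compound 3 to compound 4 (0.06 log units; within the scatter).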

Compound 4, half-maximal inhibitory concentration: > 100000 nM
Compound 4 ended at the assay's limit; the forecaster's own chance of this, stated with the estimate: 30%; at least 1.6-fold (0.22 log units) between middle value and limit.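

As far as these compounds go, compound 4, with 2-methylphenyl on the amide-type nitrogen, gives only a limit of the assay, so its true number remains unknown. Only floors can be read, an at least 1.9-fold higher number from compound 3 to compound 4 (0.27 log units; that floor lies within the scatter) and an at least 1.7-fold higher number from compound 2 to compound 4 (0.24 log units; that floor lies within the scatter), so this change shows no step beyond the scatter, although it does yield the first limit among these single-place exchanges. The result adds a second value at the edge of what the assay can read: the limit of > 100000 nM in this assay, at which 2 of the 4 values shown sit.

From the compounds shown here alone, how far past that limit compound 4 truly lies stays open. Also open, going by these compounds, is whether an amine or a carboxylic acid on this phenyl ring would give a clearly lower number.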